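The source may hold more compounds than are shown below. What is called first, only, known or untested is meant among the compounds shown, and "the series" means these compounds.

Three compounds built on a shared core were examined in an assay on CHO cells for displacement of a labelled ligand from adenosine receptor A1 (Homo sapiens), read by scintillation counting, tested at 10 uM; a lower number here means less inhibition, a higher number more inhibition at the concentration tested (going by the name of the read-out). Compound 1, `COc1ccc(-c2sc(N)c(C(=O)c3ccc(Cl)cc3)c2C)cc1`, gives 1% in this assay. Compound 2, `CC(C)(C)Cc1c(-c2cc(F)ccc2F)sc(N)c1C(=O)c1ccc(Cl)cc1`, gives 3%, and compound 3, `Cc1ccc(C(=O)c2c(CC(C)(C)C)csc2N)cc1`, gives 1%. Compound 2 thus sits among three numbers that differ from one another only within the usual scatter of such measurements; none of the three can be told apart from the others, and all show little displacement of the labelled ligand.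

Compound 4, `CC(C)(C)Cc1c(-c2cccs2)sc(N)c1C(=O)c1ccc(Cl)cc1`, has not yet been measured. It differs from compound 2 in one place: thiophen-2-yl in place of 2,5-difluorophenyl on an aromatic carbon. Within the data shown here, the compounds already measured give no step that would show how a change of this kind shifts the read-out. Since compound 2 gives 3% and its neighbours compound 1 and compound 3 give numbers in the same band, no step beyond the scatter is expected here in either direction. Compound 4 is therefore estimated at 3%, within -5% to 12%. This expectation corresponds to a step of no change at the digits printed from compound 2 to compound 4 (within the scatter).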

Compound 4, a percentage reported as inhibition, at one concentration (the size of the read-out at that concentration, not a potency): 1%
The estimate for compound 4 lay 2 percentage points above the measured number, within the range that was stated.
By their numbers in this assay, from the lowest: compounds 1, 3, 4 and 2 (each within the scatter of the next).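

Among these compounds, at this position, on the aromatic carbon next to the ring sulfur, the first step that can be read is a number 2 percentage points lower from compound 2 to compound 4 (within the scatter) in this assay, with thiophen-2-yl in place of 2,5-difluorophenyl. This read-out therefore does not tell a six-membered aromatic ring of carbon only, bearing fluorine, from a five-membered aromatic ring with a sulfur, and with either group the displacement of the labelled ligand stays small. No measured evidence bears on why this is so.

As far as these compounds go, it remains open whether a group of another kind at this same position, such as a piperidine, a carboxylic acid or a longer chain like n-hexyl, would give a step beyond the scatter. A reading at one concentration also leaves the potency of these compounds undefined.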